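A few compounds are considered here, and "the series" means these few. Any claim that something is new, unique, unknown or untested is made for them only; others in the source may bear on it.

Measured in a functional assay on HCT-116 cells (Homo sapiens), read by MTT assay, with a stated time of 72 h; on this read-out lower numbers stand for stronger inhibition and higher numbers for weaker inhibition:
- compound 1 `C#Cc1cn([C@@H]2O[C@H](CO)[C@@H](O)[C@H]2O)c2ncnc(OC)c12`: 5140 nM
- compound 2 `C#Cc1cn([C@@H]2O[C@H](CO)[C@@H](O)[C@H]2O)c2ncnc(N(C)C)c12`: 290 nM
- compound 3 `Cc1ncnc2c1c(-c1cccs1)cn2[C@@H]1O[C@H](CO)[C@@H](O)[C@H]1O`: > 20000 nM, a limit and not a number

Compound 3 stands at the limit: the limit of > 20000 nM in this assay, at which 1 of the 3 values shown sits.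

Compound 4 `C#Cc1cn([C@@H]2O[C@H](CO)[C@@H](O)[C@H]2O)c2ncnc(C)c12` has ethynyl in place of thiophen-2-yl on an aromatic carbon of compound 3: ethynyl in place of thiophen-2-yl on an aromatic carbon.

Among the compounds with values here, no measured step makes this exact change. Within the data shown here, the one measured step, an 18-fold lower number from compound 1 to compound 2 (1.25 log units; beyond the scatter), lies elsewhere on the shared core, with ethynyl kept, and it bears on the width of the range. Both ethynyl compounds gave numbers, compound 1 at 5140 nM and compound 2 at 290 nM. A large step to a lower number in this assay is therefore expected, an at least 13-fold lower number from compound 3 to compound 4 (1.12 log units; beyond the scatter). Compound 4 is estimated at 1500 nM, with an expected range of 150 nM to 12000 nM.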

Compound 4, half-maximal inhibitory concentration: > 20000 nM
Compound 4: no number, only a limit; the forecaster's own chance of this, stated with the estimate: 10%; at least 13-fold (1.12 log units) between middle value and limit.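

Compound 4 gives > 20000 nM in this assay, a limit and not a number. Ethynyl on this aromatic carbon therefore does not alone secure a measurable value: with methyl on the shared core, the read-out is lost, shown by an at least 68-fold higher number from compound 2 to compound 4 (1.83 log units; beyond the scatter) and by an at least 3.8-fold higher number from compound 1 to compound 4 (0.59 log units; beyond the scatter). The step between compound 3 and compound 4 cannot be read, as both values are limits: the limit of > 20000 nM in this assay, at which 2 of the 4 values shown sit.

Open, as far as these compounds go, is whether a primary amine or a methylamino group in place of methyl gives a number with ethynyl kept. Also open, from the compounds shown here alone, is whether thiophen-2-yl gives a number alongside dimethylamino.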